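A few compounds are considered here, and "the series" means these few. Any claim that something is new, unique, unknown or untested is made for them only; others in the source may bear on it.

Of the compounds shown here, three sharing one core have been measured in a physicochemical assay for lipophilicity, measured as octanol-water partition; a lower number here means a more polar compound, a higher number a more lipophilic compound. Compound 1 `C#CCc1c(Cl)cc(N/C=N/OCOCC)cc1Cl` gives 3.5, compound 2 `C#CCc1c(Cl)cc(N/C=N/OCCOCC)cc1Cl` gives 3.7, and compound 3 `C#CCc1c(Cl)cc(N/C=N/OCc2ccccc2)cc1Cl` gives 4.2. Compound 3 therefore has the highest number of the three, beyond the scatter of both others. Compound 4 `C#CCc1c(Cl)cc(N/C=N/Oc2ccc(C)cc2)cc1Cl` differs from it as follows: 4-methylphenyl in place of benzyl on an oxygen. Thus 4-methylphenyl stands in place of benzyl on an oxygen, and the two compounds have the same atoms, joined differently.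

Going by the values given here, no measured step makes this exchange directly, so the evidence is indirect. Phenyl in place of ethoxy gave a number 0.70 log units higher from compound 1 to compound 3 (beyond the scatter), and phenyl in place of ethoxymethyl gave a number 0.50 log units higher from compound 2 to compound 3 (beyond the scatter), both modest. By contrast, a number 0.20 log units higher from compound 1 to compound 2 (within the scatter) stays within the scatter. On this limited evidence, a modest upward change is expected, not one larger than these steps. The expected step is a number 0.40 log units higher from compound 3 to compound 4 (beyond the scatter). For compound 4 the estimate is 4.6, with an expected range from 4.1 to 5.1.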

Compound 4, partition coefficient: 4.8
Compound 4: middle estimate off by 0.20 log units, on the low side; low and high end bracket the measured number.
By their numbers in this assay, from the lowest: compounds 1 and 2 (each within the scatter of the next); then compound 3; then compound 4.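

In this assay, 4-methylphenyl in place of benzyl on an oxygen gives a number 0.60 log units higher from compound 3 to compound 4 (beyond the scatter) even though the two groups match in every count, so joining the same atoms differently at this position is enough to change the number. Going by these compounds alone, measured against the two chains, the exchange gives a number 1.10 log units higher from compound 2 to compound 4 (beyond the scatter) and a number 1.30 log units higher from compound 1 to compound 4 (beyond the scatter), which shows a wider range at this oxygen than the earlier compounds reached. Nothing measured here accounts for the difference between the two isomers.

The compounds shown leave open how much of the step from benzyl belongs to the methyl and how much to the ring standing directly on the oxygen, which a plain phenyl there would separate. They also leave open how the number would respond to an amine or a carboxylic acid on that ring.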